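Moving the fluorine on the amide aryl group

This account rests on a few compounds, and the source may have more. Where it says the series, first, only, none or still open, it means among the compounds named here.

Measured so far:
- compound 1 `O=C(Nc1cccc(-c2oc3cc(-c4ccc(F)cc4)ccc3c(=O)c2O)c1)c1ccccc1F`: 7240 nM
- compound 2 `Cc1ccc(C(=O)Nc2cccc(-c3oc4cc(-c5ccc(F)cc5)ccc4c(=O)c3O)c2)cc1`: 4350 nM
- compound 3 `O=C(Nc1cccc(-c2oc3cc(-c4ccc(F)cc4)ccc3c(=O)c2O)c1)c1cccc(F)c1`: 2510 nM

In a functional assay on MDA-MB-231 cells (Homo sapiens) for antiproliferative activity, read by CCK-8 assay, with a stated time of 72 h (on this read-out higher numbers stand for weaker inhibition and lower numbers for stronger inhibition), compound 1 gives the highest number of the three. The nearest is compound 2, a 1.7-fold lower number from compound 1 to compound 2 (0.22 log units; within the scatter). The furthest is compound 3, a 2.9-fold lower number from compound 1 to compound 3 (0.46 log units; beyond the scatter).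

Compound 4 `Cc1cc(C(=O)Nc2cccc(-c3oc4cc(-c5ccc(F)cc5)ccc4c(=O)c3O)c2)ccc1F` is not yet measured. It differs from compound 1 in one place: 4-fluoro-3-methylphenyl in place of 2-fluorophenyl on a carbonyl carbon.

Both changes away from 2-fluorophenyl at this carbonyl carbon brought lower numbers, a 1.7-fold lower number from compound 1 to compound 2 (0.22 log units; within the scatter) and a 2.9-fold lower number from compound 1 to compound 3 (0.46 log units; beyond the scatter), the second beyond the scatter. Compound 4 also replaces 2-fluorophenyl, now with a fluorine and a methyl elsewhere on the ring. A modest step down is therefore expected, a 2.6-fold lower number from compound 1 to compound 4 (0.41 log units; beyond the scatter). Compound 4 is estimated at 2800 nM, within 1100 nM to 7000 nM.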

Compound 4, half-maximal inhibitory concentration: 7440 nM
Beside the measured number, compound 4's estimate is 2.7-fold (0.42 log units) below it; the whole stated range lies below it.
By their numbers in this assay, from the lowest: compounds 3, 2, 1 and 4 (each within the scatter of the next, the first and the last beyond it).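

In this assay swapping 2-fluorophenyl for 4-fluoro-3-methylphenyl gives a 1.0-fold higher number from compound 1 to compound 4 (0.01 log units; within the scatter) and so no gain, which shows that leaving 2-fluorophenyl does not by itself lower the number. Against 4-methylphenyl the step is a 1.7-fold higher number from compound 2 to compound 4 (0.23 log units; within the scatter) and against 3-fluorophenyl it is a 3.0-fold higher number from compound 3 to compound 4 (0.47 log units; beyond the scatter) and so, of these two groups, only 3-fluorophenyl is clearly separated from the new one. No measurement shown here offers an explanation for these steps. The aryl groups shown carry only fluorine or methyl, so the effect of a methoxy group, an amine or a pyridine ring at this carbonyl carbon remains open.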